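Benzylsulfanyl in place of anilino on a nucleoside core

This account rests on a few compounds, and the source may have more. Where it says the series, first, only, none or still open, it means among the compounds named here.

Measured compounds:
compound 1, `OC[C@H]1OC(n2cnc3c(Nc4ccccc4)nccc32)[C@H](O)[C@@H]1O`: 4%
compound 2, `OCCNc1[nH]ccc2ncnc1-2`: 3%

The two measured compounds were both tested in a functional assay (Homo sapiens) for inhibition of Nucleic Acid, tested at 100 uM; on this read-out higher numbers stand for more inhibition at the one concentration tested (going by the name of the read-out) and lower numbers for less inhibition. Compound 1 gives 4% in this assay, and compound 2 gives 3%. Compound 1 holds the higher of the two numbers, but its nearest neighbour, compound 2, lies only a single percentage point lower, a gap within the scatter of the measurement, so no order between them can be claimed. Both values show little inhibition at the concentration tested.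

The step followed here leads from compound 1 to compound 3, `OC[C@H]1OC(n2cnc3c(SCc4ccccc4)nccc32)[C@H](O)[C@@H]1O`, which has not been measured. The change is benzylsulfanyl in place of anilino on an aromatic carbon. Among the measured compounds shown here, no step between measured compounds is available for comparison, so the expected size rests only on the values of compound 1 and compound 2, which both sit near the bottom of the scale.

Compound 3 is expected to remain in the same low region, with a step of a number 1 percentage points higher from compound 1 to compound 3 (within the scatter) that is not expected to exceed the scatter in either direction. For compound 3 the estimated value in this assay is 5%, within a range from -8% to 18%.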

Compound 3, a percentage reported as inhibition, at one concentration (the size of the read-out at that concentration, not a potency): 30%
Beside the measured number, compound 3's estimate is 25 percentage points below it, and the stated range ends below it.
By their numbers in this assay, from the lowest: compounds 2 and 1 (each within the scatter of the next); then compound 3.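

In this assay, the exchange of anilino for benzylsulfanyl on the aromatic carbon next to the ring nitrogen brings a number 26 percentage points higher from compound 1 to compound 3 (beyond the scatter). This shows that the read-out responds to a change at this position, something the earlier values, both near the bottom of the scale, gave no sign of. The exchange keeps the six-membered aromatic ring of carbon only but replaces the nitrogen link and its hydrogen-bond donor with a sulfur link and one more carbon, and nothing available ties the rise to any one of these differences.

On these data alone, what remains open is which of these differences matters: benzylamino would keep the extra carbon with a nitrogen link, while phenylsulfanyl would keep the sulfur without that carbon, and each would differ from compound 3 in one place. As far as these compounds go, it is also open whether a longer chain, such as 2-phenylethylsulfanyl, or a chlorine on the phenyl ring would carry the read-out further, and the single concentration tested gives no potency for compound 3.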